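This account rests on a few compounds, and the source may have more. Where it says the series, first, only, none or still open, it means among the compounds named here.

Working notes on the series. All compounds share the core of compound 1 `O=C(CCc1cccc2c1B(O)OC2)Nc1ccc(Cl)cc1` and differ in one group on an aromatic carbon. In a functional assay on HCT-116 cells (Homo sapiens) for antiproliferative activity, read by MTT assay, with a stated time of 72 h (a lower number here means a stronger inhibitor, a higher number a weaker inhibitor), compound 1 gives 12000 nM, compound 2 `C#Cc1ccc(NC(=O)CCc2cccc3c2B(O)OC3)cc1` gives 45000 nM and compound 3 `CC(C)(C)OC(=O)Nc1ccc(NC(=O)CCc2cccc3c2B(O)OC3)cc1` gives 24000 nM. Compound 3 stands within the scatter of both others, with a 2.0-fold higher number from compound 1 to compound 3 (0.30 log units; within the scatter) and a 1.9-fold lower number from compound 2 to compound 3 (0.27 log units; within the scatter).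

The next compound is compound 4 `O=C(CCc1cccc2c1B(O)OC2)Nc1ccc(-c2ccccc2)cc1`, and the change is phenyl in place of (tert-butoxycarbonyl)amino on an aromatic carbon. In words, this is phenyl in place of (tert-butoxycarbonyl)amino on an aromatic carbon, para to a large group.

All three measured steps bear on this change, since each swaps one group at this same place. Only one lies beyond the scatter, the modest 3.8-fold higher number from compound 1 to compound 2 (0.57 log units; beyond the scatter). Compound 3 carries the largest of the three groups, yet its value of 24000 nM stays within the scatter of compound 1 and compound 2. Within the data shown here, none of the measured compounds carries a ring at this place, so the data give no firm direction. A step in this assay within the scatter is therefore expected, with a modest step in either direction still possible.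

The estimated step is a 1.2-fold lower number from compound 3 to compound 4 (0.08 log units; within the scatter). Compound 4 is expected at 20000 nM, with an estimated range of 7000 nM to 60000 nM.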

Compound 4, half-maximal inhibitory concentration: 13000 nM
Compound 4: the middle estimate sits 1.5-fold (0.19 log units) above what was measured, and the stated range covers the measured number.
By their numbers in this assay, from the lowest: compounds 1, 4, 3 and 2 (each within the scatter of the next, the first and the last beyond it).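

Among these compounds, the phenyl group of compound 4 is the first ring at this place, and in this assay its six-membered aromatic ring of carbon only leaves the number within the scatter of two earlier compounds, with a 1.1-fold higher number from compound 1 to compound 4 (0.03 log units; within the scatter) and a 1.8-fold lower number from compound 3 to compound 4 (0.27 log units; within the scatter) as the steps. The series now holds a second step beyond the scatter, a 3.5-fold lower number from compound 2 to compound 4 (0.54 log units; beyond the scatter), so compound 2 stands apart from both compound 1 and compound 4, although compound 3 goes against a clean split by lying within the scatter of all three others. Nothing available bears on why these groups give these numbers.

Open, from the compounds shown here alone, is whether an amine, a carboxylic acid or a longer chain at this place would give a number in line with compound 1 and compound 4 or one in line with compound 2. Also open, going by these compounds, is whether a saturated ring such as cyclohexyl, or a phenyl carrying a methoxy group of its own, would stay within the scatter of compound 4 in this assay.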